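This account rests on a few compounds, and the source may have more. Where it says the series, first, only, none or still open, it means among the compounds named here.

Measured so far:
- compound 1, `COc1cc(-c2cc(/C=C/C(=O)c3ccc(N)cc3)[nH]n2)cc(OC)c1OC`: 98%
- compound 2, `COc1ccc(-c2cc(/C=C/C(=O)c3ccc(N)cc3)[nH]n2)cc1OC`: 104%
- compound 3, `COc1cc(C(=O)/C=C/c2cc(-c3cc(OC)c(OC)c(OC)c3)n[nH]2)cc(OC)c1OC`: 103%

All three values come from a functional assay on KM12 cells (Homo sapiens) for cytotoxicity, read by sulforhodamine B assay, with a stated time of 48 h, tested at 0.1 uM; a lower number here means a stronger effect, a higher number a weaker effect of the compound at the concentration tested. In this assay compound 1 gives 98%, compound 2 gives 104% and compound 3 gives 103%; each of these numbers sits close to what untreated cells would show, so none of the three compounds has a clear effect at this concentration.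

Compound 2 arises from compound 1 by one change, (hydrogen in place of methoxy on an aromatic carbon), and this step in this assay is a number 6 percentage points higher from compound 1 to compound 2 (within the scatter).

Compound 3 is built on a different core; how it differs from compound 1 is not broken down here.

Compound 4, `COc1ccc(-c2cc(/C=C/C(=O)c3cc(OC)c(OC)c(OC)c3)[nH]n2)cc1OC`, has not yet been measured. It arises from compound 3 by hydrogen in place of methoxy on an aromatic carbon, the same change as from compound 1 to compound 2, at a place described in the same words. Because the earlier step was a number 6 percentage points higher from compound 1 to compound 2 (within the scatter), the step from compound 3 to compound 4 is expected to be about a number 1 percentage points higher from compound 3 to compound 4 (within the scatter) in this assay. Compound 4 is therefore estimated at 104%, with a likely range from 92% to 116%.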

Compound 4, a percentage reported as activity, at one concentration (the size of the read-out at that concentration, not a potency): 92%
Compound 4: the middle estimate sits 12 percentage points above what was measured; the measured number falls inside the stated range.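

In this assay, putting hydrogen in place of a methoxy on an aromatic carbon gives a number 11 percentage points lower from compound 3 to compound 4 (beyond the scatter), a real but small shift at this single concentration. The same swap therefore cannot be assumed to have the same outcome on a different core, since its result here differs from the one seen on the core of compound 1: the same change on two cores in this assay, a number 6 percentage points higher (within the scatter) from compound 1 to compound 2 and a number 11 percentage points lower (beyond the scatter) from compound 3 to compound 4, 17 percentage points apart, beyond the scatter of two such steps. For the compounds shown here, this shows that the effect of the change depends on the compound carrying it, but with only two pairs it gives no rule for other cores and no explanation for the difference, and a reading at one concentration says nothing about potency.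

The compounds shown leave open what would happen if a hydroxyl group or a chlorine atom, rather than hydrogen, took the place of the methoxy. They also leave open whether the difference between the two cores would hold at other concentrations or in other cell lines.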